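Moving the Last Hydroxyl to the Ring Position That Works

This account rests on a few compounds, and the source may have more. Where it says the series, first, only, none or still open, it means among the compounds named here.

Measured so far:
- compound 1 `Oc1ccc(-c2cc(-c3ccccc3O)cc(-c3ccccc3O)n2)cc1`: 360 nM
- compound 2 `Oc1ccc(-c2cc(-c3ccccc3O)cc(-c3ccc(O)cc3)n2)cc1`: 980 nM
- compound 3 `Oc1ccc(-c2cc(-c3cccc(O)c3)cc(-c3ccccc3O)n2)cc1`: a limit only, > 50000 nM

The three measured compounds share one core carrying three hydroxyphenyl rings, and differ only in where the hydroxyl sits on one of those rings. In a functional assay on DU-145 cells (Homo sapiens) for cytotoxicity, read by CCK-8 assay, with a stated time of 4 days (a higher number here means a weaker inhibitor, a lower number a stronger inhibitor), compound 1 gives 360 nM, the lowest of the two numbers shown. Compound 2 gives 980 nM in this assay, and the step is a 2.7-fold higher number from compound 1 to compound 2 (0.43 log units; beyond the scatter). Compound 3 reaches only the limit of this assay, > 50000 nM (the limit of > 50000 nM in this assay, at which 1 of the 3 values shown sits). That step, an at least 130-fold higher number from compound 1 to compound 3 (2.14 log units; beyond the scatter), shows how strongly the result depends on where the hydroxyl stands.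

Compound 4 `Oc1ccccc1-c1cc(-c2ccccc2O)nc(-c2ccccc2O)c1` has not been measured. It differs from compound 1 as follows: 2-hydroxyphenyl in place of 4-hydroxyphenyl on an aromatic carbon. This is the reverse of the change that gave compound 2, so the step from compound 1 to compound 2 bears on it most directly; in mirror image it suggests a modest gain. The step to compound 3 is less directly relevant, since it concerns a different hydroxyl position.

For compound 4 in this assay, the expected result is 180 nM, in a range from 60 nM to 600 nM, an estimated step of a 2.0-fold lower number from compound 1 to compound 4 (0.30 log units; within the scatter).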

Compound 4, half-maximal inhibitory concentration: 5040 nM
The estimate for compound 4 lay 28-fold (1.45 log units) below the measured number, and the stated range ends below it.
By their numbers in this assay, from the lowest: compound 1; then compound 2; then compound 4. At a limit, above all of these: compound 3.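

Compound 1's 4-hydroxyphenyl, on the carbon next to the ring nitrogen, now proves to matter: putting a 2-hydroxyphenyl there, so that all three rings carry the same group, is costly in this assay (a 14-fold higher number from compound 1 to compound 4 (1.15 log units; beyond the scatter)). The earlier steps shown here both moved away from a 2-hydroxyphenyl and both raised the number, which made that group look like the better choice, but this step shows that it is not better everywhere, so a group has to be judged at its own place on the shared core. Nothing measured here accounts for the size of this loss.

The compounds shown leave open whether the hydroxyl of the 4-hydroxyphenyl is needed at all, since every ring here carries a hydroxyl, and a methoxy group, an amine or a carboxylic acid in its place would test that directly. They also leave open how a 3-hydroxyphenyl would behave on the carbon next to the ring nitrogen, and whether a plain phenyl ring there would keep any of the activity of compound 1.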